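Cytotoxicity notes: benzyl amide to isobutyl amide in the series

The source may hold more compounds than are shown below. What is called first, only, known or untested is meant among the compounds shown, and "the series" means these compounds.

Values in an ADME assay on HELF cells (Homo sapiens) for cytotoxicity, with a stated time of 3 days; a lower number here means that less compound is tolerated, a higher number that more compound is tolerated:

- Compound 1 `CC(C)[C@H](NC(=O)[C@@]1(Cc2ccccc2)CCN1C(=O)OCc1ccccc1)C(N)=O` gives a limit of the assay, > 100000 nM.
- Compound 2 `C[C@H](NC(=O)[C@@]1(Cc2ccccc2)CCN1C(=O)OCc1ccccc1)C(=O)NCc1ccccc1` gives a limit of the assay, >= 20000 nM.
- Compound 3 `C[C@H](NC(=O)[C@]1(Cc2ccccc2)CCN1C(=O)OCc1ccccc1)C(=O)NCc1ccccc1` gives 100000 nM.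

Compound 2 stands at a limit, so its position against the other two is only partly readable: compound 1 also sits at a limit, while compound 3 alone gives a number. No toxicity worth the name is seen for any of the three. Both measured steps are accordingly uninformative: a step that the two limits leave unreadable from compound 1 to compound 2 and a step that the limit leaves unreadable from compound 2 to compound 3, the latter being a change of configuration only (the fact that compounds 2 and 3 differ only in the configuration as drawn).

The change to compound 4 `CC(C)CNC(=O)[C@H](C)NC(=O)[C@@]1(Cc2ccccc2)CCN1C(=O)OCc1ccccc1` is isopropyl in place of phenyl on a saturated chain carbon bound to an amide-type nitrogen. For the measured compounds named here, no measured step covers this kind of change, and the limits the limit of > 100000 nM in this assay, at which 1 of the 3 values shown sits, and the limit of >= 20000 nM in this assay, at which 1 of the 3 values shown sits, give no foothold for any direction. The two readable facts are that every compound made so far is tolerated at high concentration and that neither a change of the amide substituent nor of configuration has moved the value out of the limit region.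

For compound 4 the expectation is therefore no step beyond the scatter: a step that the limit leaves unreadable from compound 2 to compound 4 is the estimated change. Compound 4 is estimated at 100000 nM, with a range of 20000 nM to 200000 nM, most likely reported as a limit again.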

Compound 4, minimum cytotoxic concentration: > 100000 nM
Compound 4: only a limit was reported; the forecaster's own chance of this, stated with the estimate: 70%; the middle value lies on the limit itself.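

In this assay compound 4 gives > 100000 nM, a limit of the assay. No new step can be read from compound 1 or compound 2 to compound 4, as each pair joins two limits: the limit of > 100000 nM in this assay, at which 2 of the 4 values shown sit.

The compounds shown leave open whether isobutylcarbamoyl in place of benzylcarbamoyl changes the tolerated concentration in this assay at all.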